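The source may report more compounds than this note shows. Statements on the series, on what has been measured and on what is new or still open speak of the compounds shown alone.

Of the compounds shown here, two have so far been measured in an assay on CHO cells for displacement of a labelled ligand from Alpha-2B adrenergic receptor (Homo sapiens); on this read-out lower numbers stand for stronger inhibition and higher numbers for weaker inhibition. Compound 1, `CC(Oc1ccccc1/C=N/O)C1=NCCN1`, gives 708 nM. Compound 2, `COC1(C2=NCCN2)COc2cccc(-c3ccccc3)c2O1`, gives 1070 nM. Compound 1 stands at the lower end of these two numbers, but the gap to compound 2 lies within the usual scatter of the assay, so the two cannot be told apart on this read-out.

Compound 3, `CC(Oc1ccccc1)C1=NCCN1`, has not yet been measured. It differs from compound 1 by a hydrogen atom in place of a group of 3 heavy atoms (1 carbon, 1 nitrogen, 1 oxygen; no ring), on an aromatic carbon. Within the data shown here, no measured pair in this small set shows what removing such a group does, so the step from compound 1 to compound 3 in this assay can only be anticipated: a modest weakening seems most likely, or no change beyond the scatter. For compound 3 the expected value is 1200 nM, within a range from 300 nM to 5000 nM. That corresponds to an expected step of a 1.7-fold higher number from compound 1 to compound 3 (0.23 log units; within the scatter).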

Compound 3, inhibition constant: 166 nM
Compound 3: middle estimate off by 7.2-fold (0.86 log units), on the high side; measured number below the stated range.
By their numbers in this assay, from the lowest: compound 3; then compounds 1 and 2 (each within the scatter of the next).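

At this position, on an aromatic carbon, the group of 3 heavy atoms is not needed for inhibition in this assay. Replacing it with a hydrogen atom gives a 4.3-fold lower number from compound 1 to compound 3 (0.63 log units; beyond the scatter), a step beyond the scatter, so in this pair the simpler compound has the stronger inhibition. No measurement shown here explains this step.

On these data alone, this reading rests on a single pair, so it remains open whether other groups on the same aromatic carbon, such as a methoxy group, an amine or a fluorine atom, would keep, improve or lose the inhibition seen with hydrogen. As far as these compounds go, it also remains open whether the same replacement would give a similar step at another position on the ring or on a different core.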